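The source may report more compounds than this note shows. Statements on the series, on what has been measured and on what is new or still open speak of the compounds shown alone.

Series notes. Compound 1 `COc1cc(C2CC(c3ccccc3)=NN2C(=O)OCc2ccccc2)cc(OC)c1OC` carries a benzyl carbamate on the core and a trimethoxyphenyl group. In a functional assay on A2780 cells (Homo sapiens) for antiproliferative activity, read by MTT assay, with a stated time of 48 h (on this read-out higher numbers stand for weaker inhibition of growth and lower numbers for stronger inhibition of growth), compound 1 returns only a limit, > 10000 nM. Compound 2 `COc1cccc(C2=NN(C(=O)OCc3ccccc3)C(c3cc(OC)c(OC)c(OC)c3)C2)c1` is the same core with a methoxy added on the aryl group; in this assay compound 2 likewise gives only a limit, > 10000 nM. The step that the two limits leave unreadable from compound 1 to compound 2 therefore cannot be sized, because both values sit at the limit of > 10000 nM in this assay, at which 2 of the 3 values shown sit. The change itself is methoxy in place of hydrogen on an aromatic carbon.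

Compound 3 `COC(=O)N1N=C(c2ccccc2)CC1c1ccc(OC)c(OC)c1` has a methyl carbamate and a dimethoxyphenyl group; how its core differs from the core of compound 1 is not broken down here. In this assay, among the measured compounds shown here, compound 3 gives 29900 nM, the only number in the set, and it is weak.

Compound 4 `COC(=O)N1N=C(c2ccccc2)CC1c1cc(OC)c(OC)cc1OC` is to be measured in this assay. It differs from compound 3 by methoxy in place of hydrogen on an aromatic carbon. This is the same kind of change as that from compound 1 to compound 2, not the same: in compound 2 the methoxy enters meta to a large group, whereas in compound 4 it enters ortho to a large group, meta to a methoxy group and para to a methoxy group.

The measured instance of this change gives no readable size, so nothing here sets a direction for the step. Compound 3 is already weak at 29900 nM, and compound 4 is expected to stay in the same weak region, with an estimated step of a 1.0-fold higher number from compound 3 to compound 4 (0.00 log units; within the scatter). The estimate for compound 4 is 30000 nM, with a range from 8000 nM to 100000 nM, and a real chance that only a limit is reported.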

Compound 4, concentration for 50% growth inhibition: > 10000 nM
Compound 4 gave a limit, no number; the forecaster's own chance of this, stated with the estimate: 45%; the middle value lies beyond the limit too.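

In this assay compound 4 gives only a limit, > 10000 nM, so no new step can be read between compound 3 and compound 4. The set now stands as follows: the limit of > 10000 nM in this assay, at which 3 of the 4 values shown sit. The compounds shown leave open whether methoxy in place of hydrogen on an aromatic carbon changes growth inhibition in either direction, and by how much, as neither instance of that change has a readable size.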